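A few compounds are considered here, and "the series" means these few. Any claim that something is new, unique, unknown or untested is made for them only; others in the source may bear on it.

Three related compounds have been tested so far in a functional assay on A549 cells (Homo sapiens) for antiproliferative activity, read by sulforhodamine B assay, with a stated time of 48 h; a higher number here means a weaker inhibitor, a lower number a stronger inhibitor. Compound 1 `COc1cc(OC)c2sc(-c3ccc(N/C=C\C(=O)c4cc(OC)c(OC)c(OC)c4)cc3)nc2c1` gives 21800 nM in this assay. Compound 2 `COc1ccc(C(=O)/C=C\Nc2ccc(-c3nc4cc(OC)c(OC)c(OC)c4s3)cc2)cc1[N+](=O)[O-]` gives 21200 nM, and compound 3 `COc1cc(C(=O)/C=C\Nc2ccc(-c3nc4cc(OC)c(OC)c(OC)c4s3)cc2)cc([N+](=O)[O-])c1OC` gives 11800 nM. Compound 3 has the lowest of the three numbers, but the gaps to compound 2 and to compound 1 are both within the scatter, so none of the three can be set apart from the others on these data.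

The next compound, compound 4 `COc1cc(C(=O)/C=C\Nc2ccc(-c3nc4cc(OC)c(OC)c(OC)c4s3)cc2)cc(OC)c1OC`, differs from compound 3 in one place: methoxy in place of nitro on an aromatic carbon. Among the compounds with values here, only one measured step bears on this change. It is a 1.8-fold lower number from compound 2 to compound 3 (0.25 log units; within the scatter), which is within the scatter and concerns a different group. Within the data shown here, no step swapping nitro for methoxy has been measured. Compound 1, which also carries three methoxy groups on the ketone-bearing ring, shows a value close to compound 3. The step of a 1.3-fold higher number from compound 3 to compound 4 (0.10 log units; within the scatter) is therefore expected to stay within the scatter. Compound 4 is estimated to give 15000 nM in this assay, within 5000 nM to 45000 nM.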

Compound 4, half-maximal inhibitory concentration: 15500 nM
The estimate for compound 4 lay 1.0-fold (0.01 log units) below the measured number, within the range that was stated.
By their numbers in this assay, from the lowest: compounds 3, 4, 2 and 1 (each within the scatter of the next).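

In this assay, nitro and methoxy at this position, ortho to a methoxy group, cannot be told apart: the swap gives a 1.3-fold higher number from compound 3 to compound 4 (0.12 log units; within the scatter). Changing the whole ring on the carbonyl carbon, 3,4,5-trimethoxyphenyl in place of 4-methoxy-3-nitrophenyl, gives a 1.4-fold lower number from compound 2 to compound 4 (0.14 log units; within the scatter), and methoxy in place of hydrogen on an aromatic carbon of the core gives a 1.4-fold lower number from compound 1 to compound 4 (0.15 log units; within the scatter), so none of these changes moves the number beyond the scatter. Methoxy in place of hydrogen can now be read on two cores, and the two readings agree: the same change on two cores in this assay, a 1.8-fold lower number (0.25 log units; within the scatter) from compound 2 to compound 3 and a 1.4-fold lower number (0.15 log units; within the scatter) from compound 1 to compound 4, 1.3-fold (0.11 log units) apart, within the scatter of two such steps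

The four compounds shown therefore do not reveal whether this position can influence the number at all. On these data alone, whether an amine, a hydroxyl group or a carboxylic acid here would give a step beyond the scatter remains open.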